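Aryl variation on the amide-type nitrogen, cyclohexyl ether series

The compounds below may be only part of what the source reports. "The series", "measured", "known", "first", "only" and "open" are said of these compounds alone.

Values in a functional assay on CRL2813 cells (Homo sapiens) for cytotoxicity, read by sulforhodamine B assay, with a stated time of 5 days; a lower number here means a stronger inhibitor, a higher number a weaker inhibitor:
Compound 1 `O=C(Nc1cccc(F)c1)N[C@H]1CC[C@H](Oc2ccc(F)cc2)CC1`: 8300 nM
Compound 2 `O=C(Nc1ccccc1)N[C@H]1CC[C@H](Oc2ccc(F)cc2)CC1`: 20000 nM

Among the measured compounds shown here, compound 1 stands lowest of the two numbers; the one step, a 2.4-fold higher number from compound 1 to compound 2 (0.38 log units; beyond the scatter), came with hydrogen in place of fluoro on an aromatic carbon. Compound 3 `COc1ccc(NC(=O)N[C@H]2CC[C@H](Oc3ccc(F)cc3)CC2)cc1` is unmeasured in this assay. Its change from compound 1: 4-methoxyphenyl in place of 3-fluorophenyl on an amide-type nitrogen. For the measured compounds named here, no measured step covers 4-methoxyphenyl; the single step bears only loosely, as it also alters the group on the amide-type nitrogen, and it was modest and upward. A modest weakening of similar size is expected, a 1.6-fold higher number from compound 1 to compound 3 (0.19 log units; within the scatter). Compound 3 is estimated at 13000 nM, range 4500 nM to 40000 nM.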

Compound 3, half-maximal inhibitory concentration: > 20000 nM
Compound 3: no number, only a limit; the forecaster's own chance of this, stated with the estimate: 10%; middle value at least 1.5-fold (0.18 log units) away from the limit.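

In this assay compound 3 gives > 20000 nM, which is a limit of the assay and not a number. Replacing 3-fluorophenyl with 4-methoxyphenyl on the amide-type nitrogen gives an at least 2.4-fold higher number from compound 1 to compound 3 (0.38 log units; beyond the scatter), so compound 1 stays lowest against a second aryl group as well as against the plain phenyl. Methoxy in place of hydrogen on an aromatic carbon gives a number no lower from compound 2 to compound 3 (the limit leaves the size open), and the size of this step cannot be read.

As far as these compounds go, whether methoxy changes anything relative to hydrogen therefore stays open. Also open, from the compounds shown here alone, is how an amine or a carboxylic acid on this aryl ring would read against compound 1.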